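A few compounds are considered here, and "the series" means these few. Any claim that something is new, unique, unknown or untested is made for them only; others in the source may bear on it.

Three compounds sharing one core were examined in a functional assay on a cell-free system (Platelet, plasma, Homo sapiens) for inhibition; on this read-out higher numbers stand for weaker inhibition and lower numbers for stronger inhibition. Compound 1, `Cc1ccc(N(CCN2CCC(OCC(=O)O)CC2)C(=O)c2cccc(C)c2)cc1`, gives 160 nM in this assay. Compound 2, `COc1cccc(C(=O)N(CCN2CCC(OCC(=O)O)CC2)c2ccc(C)cc2)c1`, differs from compound 1 by methoxy in place of methyl on an aromatic carbon; in this assay compound 2 gives 32 nM, which is a 5.0-fold lower number from compound 1 to compound 2 (0.70 log units; beyond the scatter). Compound 3, `Cc1cccc(C(=O)N(CCN2CCC(OCC(=O)O)CC2)c2ccc(Cl)cc2)c1`, differs from compound 1 by chloro in place of methyl on an aromatic carbon; in this assay compound 3 gives 310 nM, a change of a 1.9-fold higher number from compound 1 to compound 3 (0.29 log units; within the scatter).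

Compound 4, `COc1cccc(C(=O)N(CCN2CCC(OCC(=O)O)CC2)c2ccc(Cl)cc2)c1`, has not been measured in this assay. It differs from compound 3 by methoxy in place of methyl on an aromatic carbon, the same change that separates compound 1 from compound 2, made on a core that differs from that of compound 1 by chloro in place of methyl on an aromatic carbon. The change occurs twice among these compounds, once measured and once not. Going by the values given here, since the single measured instance of this change was a 5.0-fold lower number from compound 1 to compound 2 (0.70 log units; beyond the scatter), the step expected from compound 3 to compound 4 in this assay is a 5.0-fold lower number from compound 3 to compound 4 (0.70 log units; beyond the scatter), resting on that one example alone. Compound 4 is therefore estimated at 62 nM in this assay, with a range expected from 28 nM to 140 nM.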

Compound 4, half-maximal inhibitory concentration: 74 nM
For compound 4 the middle estimate is 1.2-fold (0.08 log units) below the measured one; the measured number falls inside the stated range.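

In this assay, methoxy in place of methyl on an aromatic carbon gives a 4.2-fold lower number from compound 3 to compound 4 (0.62 log units; beyond the scatter), which agrees with the earlier step on the core of compound 1: the same change on two cores in this assay, a 5.0-fold lower number (0.70 log units; beyond the scatter) from compound 1 to compound 2 and a 4.2-fold lower number (0.62 log units; beyond the scatter) from compound 3 to compound 4, 1.2-fold (0.08 log units) apart, within the scatter of two such steps. Chloro in place of methyl on an aromatic carbon reads the same way, with a 2.3-fold higher number from compound 2 to compound 4 (0.36 log units; beyond the scatter) agreeing with its earlier step: the same change on two cores in this assay, a 1.9-fold higher number (0.29 log units; within the scatter) from compound 1 to compound 3 and a 2.3-fold higher number (0.36 log units; beyond the scatter) from compound 2 to compound 4, 1.2-fold (0.08 log units) apart, within the scatter of two such steps. Among these compounds, each change therefore keeps its direction and much of its size when carried to the second core, but each comparison rests on a single pair of steps, so this does not show that either change would carry to any other core in the series, nor does it explain why the steps agree.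

The compounds shown leave open how ethoxy or fluoro would compare with methoxy, methyl and chloro at these places. They also leave open whether the steps would hold if an ester took the place of the carboxylic acid or a longer chain carried the acid.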